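Chain length versus amide-to-ester change in the sulfonamide series

The source may hold more compounds than are shown below. What is called first, only, known or untested is meant among the compounds shown, and "the series" means these compounds.

Compound 1 `CCCCCCNC(=O)CS(=O)(=O)Nc1c(C(C)C)cccc1C(C)C` in an assay on microsomes from intestine for inhibition of acyl-CoA:cholesterol acyltransferase (Oryctolagus cuniculus) (a lower number here means a stronger inhibitor, a higher number a weaker inhibitor), gives > 5000 nM, which is a limit of the assay rather than a number. Among the measured compounds shown here, it is the one value sitting at the limit of > 5000 nM in this assay, at which 1 of the 3 values shown sits. Compound 2 `CCCCCCCCCCCCNC(=O)CS(=O)(=O)Nc1c(C(C)C)cccc1C(C)C` gives 320 nM in this assay, and compound 3 `CC(C)c1cccc(C(C)C)c1NC(=O)CS(=O)(=O)Nc1c(C(C)C)cccc1C(C)C` gives 350 nM. Compound 4 `CCCCCCCCOC(=O)CS(=O)(=O)Nc1c(C(C)C)cccc1C(C)C` differs from compound 1 by octyloxy in place of hexylamino on a carbonyl carbon. For the measured compounds named here, the only measured step that bears on this change is an at least 15-fold lower number from compound 1 to compound 2 (1.19 log units; beyond the scatter), where a longer chain on the same side of the carbonyl gave a large lowering. Octyloxy is shorter than dodecyl and the ester replaces the amide, so a smaller lowering is expected than in an at least 15-fold lower number from compound 1 to compound 2 (1.19 log units; beyond the scatter). Compound 4 is estimated at 1500 nM, within 400 nM to 6000 nM. The expected step is an at least 3.3-fold lower number from compound 1 to compound 4 (0.52 log units; beyond the scatter).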

Compound 4, half-maximal inhibitory concentration: > 1000 nM
Compound 4 was reported as a limit; the forecaster's own chance of this, stated with the estimate: 25%; the middle value lies beyond the limit too.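

Compound 1 and compound 4 are both reported as limits, and the step between them cannot be read. Still open, from the compounds shown here alone, is whether octyloxy in place of hexylamino on a carbonyl carbon changes the inhibition, and in which direction.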